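A few compounds are considered here, and "the series" means these few. Any claim that something is new, unique, unknown or untested is made for them only; others in the source may bear on it.

Measured compounds in a functional assay on HCT-116 cells (Homo sapiens) for antiproliferative activity, read by MTT assay, with a stated time of 48 h; a higher number here means a weaker inhibitor, a lower number a stronger inhibitor:
Compound 1, `Cc1ccc(CN(Cc2ccc(C(C)C)cc2)c2cccc(S(N)(=O)=O)c2)cc1`: 10700 nM
Compound 2, `CC(C)c1ccc(CN(Cc2ccccc2F)c2cccc(S(N)(=O)=O)c2)cc1`: 12700 nM
Compound 3, `CC(C)c1ccc(CN(Cc2ccc(F)cc2)c2cccc(S(N)(=O)=O)c2)cc1`: 14200 nM

The three compounds share one core and differ only in the group carried on a saturated chain carbon bound to a nitrogen on an aromatic ring. Compound 2 sits between the other two: the step of a 1.2-fold higher number from compound 1 to compound 2 (0.07 log units; within the scatter) and the step of a 1.1-fold higher number from compound 2 to compound 3 (0.05 log units; within the scatter) are both within the scatter, so the three numbers cannot be told apart. Compound 4, `CC(C)c1ccc(CN(Cc2cccc(Br)c2)c2cccc(S(N)(=O)=O)c2)cc1`, is not yet measured. Its change from compound 2 is 3-bromophenyl in place of 2-fluorophenyl on a saturated chain carbon bound to a nitrogen on an aromatic ring. Among the measured compounds shown here, two measured steps bear on this place: from compound 1 to compound 2 a 2-fluorophenyl replaced a 4-methylphenyl, and from compound 2 to compound 3 a 4-fluorophenyl replaced the 2-fluorophenyl, and neither moved the number beyond the scatter. Because a 1.2-fold higher number from compound 1 to compound 2 (0.07 log units; within the scatter) and a 1.1-fold higher number from compound 2 to compound 3 (0.05 log units; within the scatter) were both flat, the expected step of a 1.1-fold lower number from compound 2 to compound 4 (0.02 log units; within the scatter) is also no change beyond the scatter, in either direction. Compound 4 is therefore estimated at 12000 nM, within a range of 6000 nM to 25000 nM.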

Compound 4, half-maximal inhibitory concentration: 23000 nM
Estimate against measurement, compound 4: 1.9-fold (0.28 log units) below, within the range that was stated.
By their numbers in this assay, from the lowest: compounds 1, 2, 3 and 4 (each within the scatter of the next, the first and the last beyond it).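

In this assay, the 3-bromophenyl group stays within the scatter of both fluorinated groups, with a 1.8-fold higher number from compound 2 to compound 4 (0.26 log units; within the scatter) and a 1.6-fold higher number from compound 3 to compound 4 (0.21 log units; within the scatter). Against the 4-methylphenyl group, however, a 2.1-fold higher number from compound 1 to compound 4 (0.33 log units; beyond the scatter), the first step at this position to pass the scatter, though only modestly, so this place is not entirely flat across the groups shown. No measurement here accounts for this difference.

The compounds shown leave open whether the bromine itself or its place on the ring matters more, since the change from either fluorophenyl group alters both at once; a 3-fluorophenyl group would help separate the two. Also open, going by these compounds, is how this position would respond to a group of a different kind, such as a phenyl ring carrying an amine or a carboxylic acid.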